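Piperidine attachment point and rat microsomal half-life

This account rests on a few compounds, and the source may have more. Where it says the series, first, only, none or still open, it means among the compounds named here.

Compound 1 `Nc1ncnc2c1c(Oc1cccc(Cl)c1)nn2CC1CCNCC1` is the reference for this step. In an ADME assay on microsomes from liver (Rattus norvegicus) for metabolic stability, read by LC-MS, tested at 1 uM (on this read-out lower numbers stand for a shorter-lived compound and higher numbers for a longer-lived compound), compound 1 gives > 1 h, which is a limit of the assay and not a number. Within the data shown here, compound 2 `Cc1cccc(Oc2nn(C(C)(C)C)c3ncnc(N)c23)c1` differs from compound 1 in several places; in this assay compound 2 gives 0.07 h, and no single step joins the two, so the pair only shows that the series spans both ends of the read-out, with compound 1 at the limit of > 1 h in this assay, at which 1 of the 2 values shown sits.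

Compound 3 `Nc1ncnc2c1c(Oc1cccc(Cl)c1)nn2CC1CCCNC1` is not yet measured. It differs from compound 1 by piperidin-3-yl in place of piperidin-4-yl on a saturated chain carbon bound to an aromatic nitrogen.

Among the measured compounds shown here, no measured step of this kind is available. Since the two rings share the same atoms and one donor and one acceptor each, the step from compound 1 to compound 3 is expected to stay within the scatter, so a number no higher from compound 1 to compound 3 (the limit leaves the size open) is the expectation. Compound 3 is therefore estimated at 1 h in this assay, within 0.4 h to 2.5 h, with a fair chance that only a limit is again reported.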

Compound 3, half-life: > 1 h
Compound 3: a limit, no number (the forecaster's own chance of this, stated with the estimate: 50%); the middle value lies on the limit itself.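

In this assay, compound 1 and compound 3 both end at a limit and not a number, so no step can be read between them: the limit of > 1 h in this assay, at which 2 of the 3 values shown sit.

On these data alone, the actual half-lives of both compounds stay open, as does any difference between piperidin-4-yl and piperidin-3-yl.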